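From cyano to trifluoromethyl at an assay limit

This account rests on a few compounds, and the source may have more. Where it says the series, first, only, none or still open, it means among the compounds named here.

In a physicochemical assay for solubility, using the shake flask method, measured as kinetic solubility, with a stated time of 20 h, at pH 2 (on this read-out lower numbers stand for lower solubility and higher numbers for higher solubility), compound 1 (`COc1ccnc(Nc2cc3[nH]c(-c4cccc(C(F)(F)F)c4)nc3cn2)c1`) gives < 5000 nM, which is a limit and not a number. Compound 2 (`Fc1cnc(Nc2cc3[nH]c(-c4cccc(C(F)(F)F)c4)nc3cn2)c(F)c1`) gives < 5000 nM, also a limit. Compound 3 (`N#Cc1ccc(Nc2cc3[nH]c(-c4cccc(C(F)(F)F)c4)nc3cn2)nc1`) gives < 5000 nM, again a limit, so it has no exact value of its own. The whole set looks the same: the limit of < 5000 nM in this assay, at which 3 of the 3 values shown sit.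

Compound 4 (`FC(F)(F)c1ccc(Nc2cc3[nH]c(-c4cccc(C(F)(F)F)c4)nc3cn2)nc1`) carries trifluoromethyl in place of cyano on an aromatic carbon. The nearest measured changes are a step that the two limits leave unreadable from compound 1 to compound 3 and a step that the two limits leave unreadable from compound 2 to compound 3, so neither offers a size or direction to carry over.

The expected result is a step that the limit leaves unreadable from compound 3 to compound 4, with nothing expected beyond the usual scatter. For compound 4 the estimate is 3000 nM, within a range of 800 nM to 6000 nM.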

Compound 4, solubility: < 5000 nM
Compound 4: a limit, no number (the forecaster's own chance of this, stated with the estimate: 85%); the middle value lies beyond the limit too.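

No step from compound 1, compound 2 or compound 3 to compound 4 can be read, since all four give a limit and no number: the limit of < 5000 nM in this assay, at which 4 of the 4 values shown sit.

From the compounds shown here alone, the true size and direction of these changes in this assay stay open.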